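Methoxy Added to a Benzyl Ring at the Cytotoxicity Limit

The source may hold more compounds than are shown below. What is called first, only, known or untested is meant among the compounds shown, and "the series" means these compounds.

Compound 1 `Oc1ccc(CNc2ncnc3c2ncn3C2CCCCO2)cc1` gives > 100000 nM in an ADME assay on MCF7 cells (Homo sapiens) for cytotoxicity, with a stated time of 72 h (on this read-out lower numbers stand for stronger inhibition and higher numbers for weaker inhibition), which is a limit of the assay and not a number.
Compound 2 `COc1ccccc1CNc1ncnc2c1ncn2C1CCCCO1` gives > 100000 nM in this assay, again a limit.
Compound 3 `COc1cc(CNc2ncnc3c2ncn3C2CCCCO2)ccc1O` gives > 100000 nM in this assay, again a limit.

The change from compound 1 to compound 3 is methoxy in place of hydrogen on an aromatic carbon, and its step is a step that the two limits leave unreadable from compound 1 to compound 3. The change from compound 2 to compound 4 `COc1cccc(OC)c1CNc1ncnc2c1ncn2C1CCCCO1` is methoxy in place of hydrogen on an aromatic carbon. The places differ: in compound 3 the methoxy sits ortho to a hydroxy group and meta to a large group, whereas in compound 4 it sits ortho to a large group and meta to a methoxy group, so this is the same kind of change, not the same change. The two cores differ by 2-methoxyphenyl in place of 4-hydroxyphenyl on a saturated chain carbon bound to a nitrogen on an aromatic ring, a step that the two limits leave unreadable from compound 1 to compound 2. Because (the limit of > 100000 nM in this assay, at which 3 of the 3 values shown sit), no measured step can be read. Compound 4 is expected to give 200000 nM, between 60000 nM and 600000 nM, in this assay. The expected step is a step that the limit leaves unreadable from compound 2 to compound 4, resting on compound 2 having reached only > 100000 nM.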

Compound 4, half-maximal inhibitory concentration: > 100000 nM
Compound 4 was reported as a limit; the forecaster's own chance of this, stated with the estimate: 80%; the middle value is on the limit's open side.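

No new step can be read from compound 2 to compound 4, since both results in this assay are limits and not numbers: the limit of > 100000 nM in this assay, at which 4 of the 4 values shown sit.

The compounds shown leave open how weak each one truly is and whether adding methoxy changes anything.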